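Replacing cyclohexylmethyl with 1-ethyl-1-methylpropyl on the shared core

This account rests on a few compounds, and the source may have more. Where it says the series, first, only, none or still open, it means among the compounds named here.

Three compounds share a core and differ only in the group on a saturated chain carbon bound to an aromatic carbon. Compound 1 `Cc1cccc(Cc2cnc(CCc3ccc(-c4ccccc4C(=O)O)cc3)[nH]2)c1` carries 3-methylphenyl there, and in an in vitro functional assay on cells for agonist activity at Bombesin receptor subtype-3 (Homo sapiens), read by luminescence and calcium flux (a higher number here means that more compound is needed for the effect, a lower number that less compound is needed), compound 1 gives 4310 nM. Compound 2 `CC(C)(C)Cc1cnc(CCc2ccc(-c3ccccc3C(=O)O)cc2)[nH]1` carries tert-butyl, and in this assay compound 2 gives 106 nM. Compound 3 `O=C(O)c1ccccc1-c1ccc(CCc2ncc(CCC3CCCCC3)[nH]2)cc1` carries cyclohexylmethyl, and in this assay compound 3 gives 642 nM, the second highest of the three numbers, with compound 2 nearest and compound 1 furthest.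

The steps among these are a 41-fold lower number from compound 1 to compound 2 (1.61 log units; beyond the scatter), a 6.7-fold lower number from compound 1 to compound 3 (0.83 log units; beyond the scatter) and a 6.1-fold higher number from compound 2 to compound 3 (0.78 log units; beyond the scatter). Compound 4 `CCC(C)(CC)Cc1cnc(CCc2ccc(-c3ccccc3C(=O)O)cc2)[nH]1` has not been measured; the change from compound 3 is 1-ethyl-1-methylpropyl in place of cyclohexylmethyl on a saturated chain carbon bound to an aromatic carbon. The incoming group, like tert-butyl in compound 2, has no ring, and the step of a 6.1-fold higher number from compound 2 to compound 3 (0.78 log units; beyond the scatter) bears most directly on it, since it runs the other way. Compound 4 is therefore expected to show a lower number than compound 3, a step of about a 3.2-fold lower number from compound 3 to compound 4 (0.51 log units; beyond the scatter). The estimate for compound 4 in this assay is 200 nM, within a range from 50 nM to 800 nM.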

Compound 4, half-maximal effective concentration: 76 nM
Compound 4: middle estimate off by 2.6-fold (0.42 log units), on the high side, and the stated range covers the measured number.
By their numbers in this assay, from the lowest: compounds 4 and 2 (each within the scatter of the next); then compound 3; then compound 1.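

The step of an 8.4-fold lower number from compound 3 to compound 4 (0.93 log units; beyond the scatter) shows that in this assay, this position gives a much lower number with 1-ethyl-1-methylpropyl than with cyclohexylmethyl, and a 57-fold lower number from compound 1 to compound 4 (1.75 log units; beyond the scatter) is the widest step among the four compounds. The earlier compounds showed only tert-butyl doing well here, whereas a 1.4-fold lower number from compound 2 to compound 4 (0.14 log units; within the scatter) now shows that a second ringless group gives a number that cannot be told apart from that of compound 2, so among the compounds shown, the two ringless groups both give lower numbers than the two ring-bearing groups, and none goes against this. No evidence is at hand to explain why these groups differ.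

Because the change from compound 3 to compound 4 removes the ring and also alters the chain, as the reading from 2-cyclohexylethyl to 2-ethyl-2-methylbutyl makes plain, these compounds cannot say which of the two matters, and a cyclohexyl group on the same saturated chain carbon would separate them. They also leave open how a hydroxyl group or an amine on the ringless group would fare at this position, since every group shown consists of carbon and hydrogen only.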